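Compound 2 to Compound 3: One Group Exchanged

This account rests on a few compounds, and the source may have more. Where it says the series, first, only, none or still open, it means among the compounds named here.

Measured in a functional assay (blood) for inhibition, with Homo sapiens as the target; a higher number here means a weaker inhibitor, a lower number a stronger inhibitor:
Compound 1 `CC(C)(C)Sc1c(CC(C)(C)C(=O)O)n(Cc2ccc(Cl)cc2)c2ccc(OCc3ccc4cc(F)ccc4n3)cc12`: 880 nM
Compound 2 `CC(C)(C)Sc1c(CC(C)(C)C(=O)O)n(Cc2ccc(Cl)cc2)c2ccc(OCc3ccc4cnccc4n3)cc12`: 980 nM

Compound 2 gives 980 nM, which lies within the scatter of the value for compound 1, so the two cannot be ranked. The next compound, compound 3 `CC(C)(C)Sc1c(CC(C)(C)C(=O)O)n(Cc2ccc(Cl)cc2)c2ccc(OCc3nc4ccccc4s3)cc12`, keeps the shared core and exchanges one group: a group of 9 heavy atoms (7 carbon, 1 nitrogen, 1 sulfur; one five-membered aromatic ring with 2 hetero atoms, one six-membered aromatic ring of carbon only) in place of a group of 10 heavy atoms (8 carbon, 2 nitrogen; 2 six-membered aromatic rings with 1 hetero atom each), on a saturated chain carbon bound to an oxygen on an aromatic ring. Among the compounds with values here, only one measured step bears on this change, and it falls at the same place: a 1.1-fold higher number from compound 1 to compound 2 (0.05 log units; within the scatter). That exchange left the number within the scatter. Within the data shown here, a single step is thin evidence, and no measured compound yet carries a five-membered aromatic ring or sulfur at this place. No change beyond the scatter is therefore expected in this assay, in either direction. The expected step is a 1.0-fold higher number from compound 2 to compound 3 (0.01 log units; within the scatter). For compound 3 the estimated value is 1000 nM, with an expected range of 450 nM to 2200 nM.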

Compound 3, half-maximal inhibitory concentration: 260 nM
Compound 3: the middle estimate sits 3.8-fold (0.59 log units) above what was measured, and the stated range ends above it.
By their numbers in this assay, from the lowest: compound 3; then compounds 1 and 2 (each within the scatter of the next).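

In this assay, the group on the saturated chain carbon bound to an oxygen on an aromatic ring now proves able to move the number beyond the scatter: 1,3-benzothiazol-2-yl gives a 3.8-fold lower number from compound 2 to compound 3 (0.58 log units; beyond the scatter), and likewise a 3.4-fold lower number from compound 1 to compound 3 (0.53 log units; beyond the scatter), whereas the earlier exchange at this place gave only a 1.1-fold higher number from compound 1 to compound 2 (0.05 log units; within the scatter). Compound 3, the only one of the three with sulfur or a five-membered aromatic ring at this place, therefore has the lowest number, with both its steps beyond the scatter. No evidence is available on what lies behind this step.

The compounds shown do not separate the sulfur from the five-membered aromatic ring, as 1,3-benzothiazol-2-yl brings both at once. From the compounds shown here alone, how a benzoxazol-2-yl group, with oxygen in place of the sulfur, or a plain phenyl group would read at this place also stays open.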